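The source may hold more compounds than are shown below. What is called first, only, known or untested is meant among the compounds shown, and "the series" means these compounds.

Compound 1 `CCCN1CCN(CCNC(=O)n2c(=O)n(C3CC3)c3ccccc32)CC1` is the reference of this small set: in an assay on isolated protein (striatum) for binding affinity to 5-hydroxytryptamine receptor 4 (Cavia porcellus), read by radioligand binding (a lower number here means a stronger inhibitor, a higher number a weaker inhibitor), compound 1 gives 8.2 nM, the lowest of the three numbers recorded. Compound 2 `CCCCN1CCN(CCNC(=O)n2c(=O)n(C3CC3)c3ccccc32)CC1` gives 13.3 nM in this assay, and a 1.6-fold higher number from compound 1 to compound 2 (0.21 log units; within the scatter). Compound 3 `CCCN1CCN(CCNC(=O)n2c(=O)n(C(C)C)c3ccccc32)CC1` gives 87.3 nM, so that an 11-fold higher number from compound 1 to compound 3 (1.03 log units; beyond the scatter). Compound 4 `CN1CCN(CCCNC(=O)n2c(=O)n(C3CC3)c3ccccc32)CC1` carries a different change: (4-methylpiperazin-1-yl)methyl in place of 4-propylpiperazin-1-yl on a saturated chain carbon, two bonds along the chain from an amide-type nitrogen. For the measured compounds named here, of the measured steps, only the one from compound 1 to compound 2 touches the same region of the molecule, the chain on the piperazine amine, and it stayed within the scatter; the large step to compound 3 concerns the aromatic nitrogen, which compound 4 leaves unchanged as cyclopropyl. Going by the values given here, no measured step covers a longer chain to the amide-type nitrogen, so the expectation in this assay rests loosely on compound 2, and a small rise is estimated, a 2.0-fold higher number from compound 1 to compound 4 (0.29 log units; within the scatter). Compound 4 is therefore expected to give about 16 nM, in a range from 5 nM to 50 nM.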

Compound 4, inhibition constant: 39.7 nM
Beside the measured number, compound 4's estimate is 2.5-fold (0.39 log units) below it, within the range that was stated.
By their numbers in this assay, from the lowest: compounds 1 and 2 (each within the scatter of the next); then compound 4; then compound 3.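

In this assay, (4-methylpiperazin-1-yl)methyl in place of 4-propylpiperazin-1-yl, on a saturated chain carbon two bonds along the chain from an amide-type nitrogen, gives a 4.8-fold higher number from compound 1 to compound 4 (0.68 log units; beyond the scatter) and so lies beyond the scatter. For the compounds shown here, the only earlier step at this end of the molecule, a 1.6-fold higher number from compound 1 to compound 2 (0.21 log units; within the scatter), stayed within it, so this end is not indifferent to every change. No measurement shown accounts for the rise.

The step alters the piperazine substituent and the chain together, and the compounds shown do not separate the two. From the compounds shown here alone, how a 4-propylpiperazin-1-yl group on the same longer chain, or a morpholine in place of the piperazine, would read remains open.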